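The compounds below may be only part of what the source reports. "The series", "measured", "known", "first", "only" and "open" are said of these compounds alone.

Three measured compounds share one core: a chain carrying a triazole ring, attached to a carbon that also bears an aromatic ring. Compound 1 (`CC[C@H](CCn1cncn1)c1ccc(C)cc1`) carries a short ethyl chain and a methyl-bearing ring; compound 2 (`c1ccc(C[C@H](CCn2cncn2)c2ccccc2)cc1`) and compound 3 (`c1ccc(C[C@@H](CCn2cncn2)c2ccccc2)cc1`) instead carry a benzyl group and a plain phenyl ring, and differ from each other only in the configuration drawn at the chain carbon. In an ADME assay on HEp-2 cells (Homo sapiens) for cytotoxicity, read by MTT assay, with a stated time of 3 days (a higher number here means that more compound is tolerated, a lower number that less compound is tolerated), compound 1 gives 75.2 ug/mL, compound 2 gives 60.9 ug/mL, and compound 3 gives 55.9 ug/mL. The three numbers sit close together: the step of a 1.1-fold lower number from compound 2 to compound 3 (0.04 log units; within the scatter) is within the scatter, which fits (the fact that compounds 2 and 3 differ only in the configuration as drawn), and the gap between compound 2 and compound 1 is also within the scatter.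

Compound 4 (`Clc1ccc([C@@H](CCn2cncn2)Cc2ccccc2)cc1`) is built from compound 2 by the change (chloro in place of hydrogen on an aromatic carbon). Among the measured compounds shown here, none of the measured steps involves a chloro group, so no measured step bears directly on this change; the only measured step, a change of configuration alone, stayed within the scatter. With no evidence for movement in either direction, compound 4 is expected to give about 55 ug/mL, within a range from 30 ug/mL to 100 ug/mL. This amounts to an expected step of a 1.1-fold lower number from compound 2 to compound 4 (0.04 log units; within the scatter), not beyond the scatter.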

Compound 4, half-maximal cytotoxic concentration: 25.9 ug/mL
For compound 4 the middle estimate is 2.1-fold (0.33 log units) above the measured one, and the stated range ends above it.
By their numbers in this assay, from the lowest: compound 4; then compounds 3, 2 and 1 (each within the scatter of the next).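

In this assay, putting chloro in place of hydrogen on an aromatic carbon, para to a large group, turns phenyl into 4-chlorophenyl and gives a 2.4-fold lower number from compound 2 to compound 4 (0.37 log units; beyond the scatter), a modest move. Among the compounds shown here, this is the first step to lie beyond the scatter: the earlier compounds sat within the scatter of each other and gave no sign that the number could move, whereas this single added atom on the ring lowers the amount of compound the cells tolerate. The result shows that the change matters here, but nothing at hand explains why the number falls with chloro in this place.

What the compounds shown leave open is whether this drop belongs to chloro itself or would also appear with another group in the same place, such as fluoro, methoxy, an amine or a carboxylic acid. Going by these compounds, it also remains open whether chloro would have the same effect on the other aromatic ring, or on compound 3, which has the opposite configuration at the chain carbon.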